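The compounds below may be only part of what the source reports. "The series", "measured", "known", "first", "only" and "open" are said of these compounds alone.

Compound 1 `CCCc1cc(NNC(=O)Nc2cc(Cl)nc(Cl)c2)nc2c1cnn2C` is the starting point. In a functional assay on SW620/5-FU cells (Homo sapiens) for cytotoxicity, read by MTT assay, with a stated time of 48 h, in the presence of a further agent that is not named here (a lower number here means that less compound is needed, a higher number that more compound is needed for the effect), compound 1 gives 38700 nM. Compound 2 `CCCc1cc(NNC(=O)Nc2cc(Cl)nc(Cl)c2)nc2c1c(C)nn2C` gives 40800 nM, and compound 3 `Cc1ccc(NC(=O)NNc2cc(-c3ccc(F)cc3)c3cnn(C)c3n2)cc1Nc1nccc(-c2cccnc2)n1` gives 33100 nM. Compound 1 stands second highest of the three numbers, all of which lie within the scatter of one another. Among the measured compounds shown here, the single measured step, a 1.1-fold higher number from compound 1 to compound 2 (0.02 log units; within the scatter), shows no movement beyond the scatter. Compound 4 `Cn1ncc2c(-c3ccc(F)cc3)cc(NNC(=O)Nc3cc(Cl)nc(Cl)c3)nc21` differs from compound 1 in one place: 4-fluorophenyl in place of propyl on an aromatic carbon. For the measured compounds named here, no measured step bears directly on this change; compound 3 carries the same 4-fluorophenyl on the shared core, with a different remaining structure, and its value sits within the scatter of compound 1. Compound 4 is therefore expected to show no step beyond the scatter, a 1.1-fold lower number from compound 1 to compound 4 (0.04 log units; within the scatter). Compound 4 is estimated at 35000 nM, within 15000 nM to 80000 nM.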

Compound 4, half-maximal effective concentration: 9150 nM
For compound 4 the middle estimate is 3.8-fold (0.58 log units) above the measured one, outside the stated range (below it).
By their numbers in this assay, from the lowest: compound 4; then compounds 3, 1 and 2 (each within the scatter of the next).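

In this assay, the aromatic carbon opposite the ring nitrogen proves responsive to its substituent: 4-fluorophenyl in place of propyl gives a 4.2-fold lower number from compound 1 to compound 4 (0.63 log units; beyond the scatter). Among the compounds shown here, this is the first single change here to pass beyond the scatter, whereas the methyl change elsewhere on the shared core gave only a 1.1-fold higher number from compound 1 to compound 2 (0.02 log units; within the scatter). Nothing measured explains the shift. From the compounds shown here alone, what remains open is whether the aromatic ring or its fluorine carries the step, and how a plain phenyl, a butyl chain or an amine would behave at this position.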